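From ethyl to bromo on the shared core

A few compounds are considered here, and "the series" means these few. Any claim that something is new, unique, unknown or untested is made for them only; others in the source may bear on it.

In a functional assay (muscle tissue) with Cavia porcellus as the target (a lower number here means that less compound is needed, a higher number that more compound is needed for the effect), compound 1 `COC(=O)C1=C(C)N=C(C)/C(=C(\O)OC)C1c1ccc(Cl)cc1` gives 8130 nM and compound 2 `CCc1ccccc1C1C(C(=O)OC)=C(C)N=C(C)/C1=C(\O)OC` gives 6.46 nM as the lower of the two numbers. Compound 3 `COC(=O)C1=C(C)N=C(C)/C(=C(\O)OC)C1c1ccccc1Br` has bromo in place of ethyl on an aromatic carbon and so carries 2-bromophenyl. Only the large step of a 1300-fold lower number from compound 1 to compound 2 (3.10 log units; beyond the scatter) bears on this, and it brought 2-ethylphenyl in place of 4-chlorophenyl. Since compound 3 keeps its group ortho to a large group, a far smaller change is expected in this assay with a slightly higher number at most likely. The estimated step is a 1.9-fold higher number from compound 2 to compound 3 (0.27 log units; within the scatter) and stays modest. The estimate for compound 3 is 12 nM with 2 nM to 70 nM as its expected range.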

Compound 3, half-maximal effective concentration: 7.59 nM
For compound 3 the middle estimate is 1.6-fold (0.20 log units) above the measured one; measured number inside the range.
By their numbers in this assay, from the lowest: compounds 2 and 3 (each within the scatter of the next); then compound 1.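

In this assay, the place ortho to a large group accepts bromo as well as ethyl: the step of a 1.2-fold higher number from compound 2 to compound 3 (0.07 log units; within the scatter) stays within the scatter. The large gain over compound 1 is therefore not tied to ethyl, since the step of a 1100-fold lower number from compound 1 to compound 3 (3.03 log units; beyond the scatter) is of similar size. Nothing on hand explains these numbers. Going by these compounds, whether an amine or a methoxy group on the same aromatic carbon would keep numbers like those of compound 2 and compound 3 remains open.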